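Two inactive coumarin amides and an anilino analogue

This account rests on a few compounds, and the source may have more. Where it says the series, first, only, none or still open, it means among the compounds named here.

Compound 1 `COc1cccc(Oc2ccc3cc(NC(=O)c4ccc(OC)c(-c5cccc(OC)c5)c4)c(=O)oc3c2C)c1` — a functional assay on SK-BR-3 cells (Homo sapiens) for antiproliferative activity; a higher number here means a weaker inhibitor, a lower number a stronger inhibitor > 100000 nM
Compound 2 `COc1cccc(-c2cc(C(=O)Nc3cc4ccc(Oc5ccc(C(C)(C)C)cc5)c(C)c4oc3=O)ccc2OC)c1` — this assay > 100000 nM

Compound 1 reaches only the limit of this assay, > 100000 nM. Compound 2 likewise sits at the limit of this assay, > 100000 nM. Among the compounds with values here, compound 2 therefore stands at the upper edge of what this assay reports, and the one measured step, a step that the two limits leave unreadable from compound 1 to compound 2, cannot be sized because both ends are limits (the limit of > 100000 nM in this assay, at which 2 of the 2 values shown sit).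

Compound 3 `COc1ccc(Nc2ccc3cc(NC(=O)c4ccc(OC)c(-c5cccc(OC)c5)c4)c(=O)oc3c2C)cc1` differs from compound 2 in one place: (4-methoxyphenyl)amino in place of 4-(tert-butyl)phenoxy on an aromatic carbon. Within the data shown here, no measured step bears on this change, and the only comparison available, that between compound 1 and compound 2, is itself unreadable. Nothing in the data therefore suggests that compound 3 moves away from the limit.

For compound 3 the estimated value in this assay is 100000 nM, with a range from 20000 nM to 300000 nM. This estimate amounts to an expected step of a number no higher from compound 2 to compound 3 (the limit leaves the size open), which is taken to lie within the scatter.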

Compound 3, half-maximal inhibitory concentration: > 100000 nM
Compound 3: no number, only a limit (the forecaster's own chance of this, stated with the estimate: 70%); the middle value sits exactly at the limit.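

In this assay compound 3 gives > 100000 nM, which is a limit. The steps from compound 1 and from compound 2 to compound 3 cannot be read, because all three results are limits: the limit of > 100000 nM in this assay, at which 3 of the 3 values shown sit.

The compounds shown leave open whether any change at this place on the shared core would give a readable value.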